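Compound 1 to compound 3: adding a methoxy group

The source may hold more compounds than are shown below. What is called first, only, known or untested is meant among the compounds shown, and "the series" means these compounds.

Measured so far in a functional assay on THP-1 cells (Homo sapiens) for inhibition, read by sulforhodamine B assay, with a stated time of 48 h, tested at 50 uM; a lower number here means less inhibition of growth, a higher number more inhibition of growth at the concentration tested
compound 1 `COc1cc(/C=C/C(=O)/C=C/c2ccccc2)ccc1OCc1cn(CCCCOc2cc(=O)oc3ccccc23)nn1` gives 36%
compound 2 `COc1ccc(/C=C/C(=O)/C=C/c2ccc(OCc3cn(CCCOc4cc(=O)oc5ccccc45)nn3)c(OC)c2)cc1OC` gives 73%

Compound 1 (36%) holds the lower of the two numbers, and compound 2 (73%) stands above it by more than the usual scatter. Compound 3 `COc1ccc(/C=C/C(=O)/C=C/c2ccc(OCc3cn(CCCCOc4cc(=O)oc5ccccc45)nn3)c(OC)c2)cc1` is not yet measured. It differs from compound 1 by one change (methoxy in place of hydrogen on an aromatic carbon), with methoxy in place of hydrogen on an aromatic carbon, para to a large group, so that phenyl becomes 4-methoxyphenyl. Going by the values given here, no step between measured compounds gives the size of this change directly. Among the compounds with values here, compound 2 (73%) shows only that a higher number is reachable in this assay. A moderate rise is therefore expected, as an estimated step (a number 14 percentage points higher from compound 1 to compound 3 (beyond the scatter)). The estimated value for compound 3 is 50% within an expected range (30% to 72%).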

Compound 3, percent growth inhibition at one concentration: 45%
The estimate for compound 3 lay 5 percentage points above the measured number; the range from low to high includes it.
By their numbers in this assay, from the lowest: compounds 1 and 3 (each within the scatter of the next); then compound 2.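

In this assay, going by these compounds alone, the change from phenyl to 4-methoxyphenyl gives a number 9 percentage points higher from compound 1 to compound 3 (within the scatter), the first direct reading of this replacement. At this position on the aromatic ring, para to a large group, a methoxy group in place of hydrogen therefore leaves compound 1 and compound 3 indistinguishable in this read-out. Nothing available bears on the cause of this result.

Going by these compounds, whether an amine, a hydroxyl group or a carboxylic acid at the same position would separate from compound 1 by more than the scatter remains open. On these data alone, it is also open whether the methoxy step would read the same on a core with a longer chain, since this single pair cannot show how far the result extends beyond compound 1 and compound 3.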